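The source may report more compounds than this note shows. Statements on the series, on what has been measured and on what is new or still open speak of the compounds shown alone.

Compound 1 `N[C@@H](COP(=O)(O)OCCCOC(=O)CCc1ccccc1OCc1cccc(OC2CCCCC2)c1)C(=O)O` is the reference point for this comparison. In an assay on cells for agonist activity at probable G-protein coupled receptor 34 (Mus musculus), with a stated time of 1 h (on this read-out higher numbers stand for larger maximal responses and lower numbers for smaller maximal responses), compound 1 gives 18.8%, the highest of the three numbers measured, although the other two sit within the usual scatter of it. Compound 2 `N[C@@H](COP(=O)(O)OCCCOC(=O)CCc1ccccc1OCc1cccc(Oc2ccc(Cl)cc2)c1)C(=O)O` gives 17.8% in this assay, and compound 3 `N[C@@H](COP(=O)(O)OCCCOC(=O)CCc1ccccc1OCc1cccc(Oc2ccc(Cl)c(Cl)c2)c1)C(=O)O` gives 18%. The step of a number 1 percentage points lower from compound 1 to compound 2 (within the scatter) and the step of a number 0.8 percentage points lower from compound 1 to compound 3 (within the scatter) each exchange the cyclohexyl on the oxygen for a chlorinated phenyl group, and neither moves the maximal response beyond the scatter; the step of a number 0.2 percentage points higher from compound 2 to compound 3 (within the scatter) adds a second chloro and again changes little. Compound 4 `N[C@@H](COP(=O)(O)OCCCOC(=O)CCc1ccccc1OCc1cccc(Oc2ccc(Br)cc2)c1)C(=O)O` makes a related change: 4-bromophenyl in place of cyclohexyl on an oxygen on an aromatic ring. The two steps that bear on this, a number 1 percentage points lower from compound 1 to compound 2 (within the scatter) and a number 0.8 percentage points lower from compound 1 to compound 3 (within the scatter), were both flat, so no movement beyond the scatter is expected from this change in this assay. Compound 4 is therefore expected to reach about 18% in this assay, somewhere between 12% and 24%. The expected step is a number 0.8 percentage points lower from compound 1 to compound 4 (within the scatter).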

Compound 4, largest response reached (Emax), in percent of the reference or control that the assay uses: 17.7%
The estimate for compound 4 lay 0.3 percentage points above the measured number, within the range that was stated.
By their numbers in this assay, from the lowest: compounds 4, 2, 3 and 1 (each within the scatter of the next).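

In this assay, the step of a number 0.1 percentage points lower from compound 2 to compound 4 (within the scatter) shows that bromo in place of chloro on the aromatic carbon has no effect that can be read. The steps of a number 1.1 percentage points lower from compound 1 to compound 4 (within the scatter) and a number 0.3 percentage points lower from compound 3 to compound 4 (within the scatter) extend this: cyclohexyl, 4-chlorophenyl, 3,4-dichlorophenyl and 4-bromophenyl on this oxygen all give the same maximal response within the scatter, so neither the kind of ring nor the halogen on it separates these compounds. Nothing available explains why the response stays flat across these groups.

As far as these compounds go, whether a ring carrying an amine or a carboxylic acid, or a longer alkyl chain in place of the ring, would shift the response remains open. So does whether a change elsewhere on the shared core would move it.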